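The compounds below may be only part of what the source reports. "The series", "measured", "known", "first", "only" and "open" are said of these compounds alone.

In an ADME assay on MT4 cells (Homo sapiens) for activation, read by MTT assay (on this read-out lower numbers stand for higher toxicity in this test and higher numbers for lower toxicity in this test), compound 1 `Cc1c(Cc2c(F)cccc2Cl)nc(SC(C)C)[nH]c1=O` gives > 76000 nM, which is a limit of the assay and not a number. Compound 2 `CCC(C)Sc1nc(Cc2c(F)cccc2Cl)c(C)c(=O)[nH]1` gives > 73000 nM, which is also a limit, so its standing is known only through that bound and no exact value is available for either compound. Within the data shown here, the one measured step, a step that the two limits leave unreadable from compound 1 to compound 2, is methyl in place of hydrogen on a saturated chain carbon, two bonds along the chain from a sulfur. It has no readable size and lies at a different place from the next change, so it offers no size to carry over.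

Compound 3 `CCC(C)Sc1nc(C(CC)c2c(F)cccc2Cl)c(C)c(=O)[nH]1` differs from compound 2 by ethyl in place of hydrogen on a saturated chain carbon bound to two aromatic carbons. Among the measured compounds shown here, no measured step covers this place. The expectation in this assay therefore rests on compound 2 at > 73000 nM, a limit, and foresees no step beyond the scatter. The expected change is an at least 1.2-fold lower number from compound 2 to compound 3 (0.08 log units; that floor lies within the scatter). For compound 3 the estimated half-maximal cytotoxic concentration is 60000 nM, with an expected range of 20000 nM to 120000 nM.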

Compound 3, half-maximal cytotoxic concentration: > 3000 nM
Compound 3 gave a limit, no number (the forecaster's own chance of this, stated with the estimate: 55%); the middle value does not contradict the limit.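

In this assay compound 3 gives > 3000 nM, which is a limit of the assay and not a number. Among these compounds, compound 2 also stands at a limit, so no step from compound 2 to compound 3 can be read. The compounds shown leave open what size of change, if any, ethyl in place of hydrogen brings at this place.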